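Removing a Bulky Amine Group: Expected Effect on Cell Tolerance

The source may hold more compounds than are shown below. What is called first, only, known or untested is meant among the compounds shown, and "the series" means these compounds.

Compound 3 `CCCCOc1ccc(-c2c(NC(C)(C)CC(C)(C)C)nc3ncccn23)cc1` was tested in a toxicity assay on A549 cells (Homo sapiens) for cytotoxicity, read by luminescence and CellTiter-Glo, with a stated time of 48 h (a lower number here means that less compound is tolerated, a higher number that more compound is tolerated), where it gives 49000 nM. That is the higher of the two plain numbers shown; the nearest is compound 1 `CCCCOc1ccc(-c2nc3ncccn3c2NCC2CCCCC2)cc1`, which gives 35000 nM in this assay, a gap within the scatter. Compound 2 `CCCCOc1ccc(-c2nc3ncccn3c2N)cc1` gives only a limit of the assay, > 100000 nM, in this assay. Compound 4 `CCCCOc1ccc(-c2c(N)nc3ncccn23)cc1` differs from compound 3 by hydrogen in place of 1,1,3,3-tetramethylbutyl on a nitrogen on an aromatic ring. Within the data shown here, one measured step bears on this: the loss of a comparable group from a ring nitrogen of the shared core, an at least 2.8-fold higher number from compound 1 to compound 2 (0.45 log units; beyond the scatter), which reached (the limit of > 100000 nM in this assay, at which 1 of the 3 values shown sits). The expected step is therefore of that kind, a 2.4-fold higher number from compound 3 to compound 4 (0.39 log units; beyond the scatter). Compound 4 is estimated to give about 120000 nM in this assay, within 50000 nM to 300000 nM, quite possibly again reported only as a limit.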

Compound 4, half-maximal cytotoxic concentration: > 100000 nM
Compound 4: only a limit was reported (the forecaster's own chance of this, stated with the estimate: 65%); the middle value is on the limit's open side.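

Replacing 1,1,3,3-tetramethylbutyl with hydrogen on this nitrogen gives an at least 2.0-fold higher number from compound 3 to compound 4 (0.30 log units; that floor lies within the scatter), so this step alone cannot be told apart from ordinary variation between repeated measurements. Its true size may be larger, since the value for compound 4 is only a limit. What is new is that both compounds shown with a plain amino group, compound 2 and compound 4, now stop at the same limit: the limit of > 100000 nM in this assay, at which 2 of the 4 values shown sit.

Going by these compounds, how far past that limit compound 4 lies remains unknown. Also open, on these data alone, is what a short chain on this nitrogen, such as methyl or ethyl, would give.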